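The compounds below may be only part of what the source reports. "The series", "measured", "known", "first", "only" and "open" are said of these compounds alone.

Measured so far:
compound 1, `C#CCN(C)Cc1cccc(NC(=O)CCCCCC(=O)NO)c1`, gives 4290 nM
compound 2, `C#CCN(C)Cc1cccc(NC(=O)CCCCCCC(=O)NO)c1`, gives 420 nM
compound 3, `C#CCN(C)Cc1ccc(NC(=O)CCC(=O)NO)cc1`, gives > 10000 nM

These values come from a functional assay on DU-145 cells (Homo sapiens) for inhibition, read by MTT assay, with a stated time of 48 h; on this read-out lower numbers stand for stronger inhibition of growth and higher numbers for weaker inhibition of growth. Compound 1 and compound 2 share one core and differ only in the chain that ends in the hydroxamic acid: (hydroxycarbamoyl)methyl in place of hydroxycarbamoyl on a saturated chain carbon, five bonds along the chain from a carbonyl carbon. That change produced a 10-fold lower number from compound 1 to compound 2 (1.01 log units; beyond the scatter). For compound 3 the value in this assay is only a limit of the assay, > 10000 nM; this is the limit (the limit of > 10000 nM in this assay, at which 1 of the 3 values shown sits). Compound 3 has a different core, and the difference between the two cores is not broken down here. Compound 4, `C#CCN(C)Cc1ccc(NC(=O)CCCC(=O)NO)cc1`, is not yet measured and differs from compound 3 by the same kind of change: (hydroxycarbamoyl)methyl in place of hydroxycarbamoyl on a saturated chain carbon, two bonds along the chain from a carbonyl carbon. The place is not the same, though: in the first pair the change sits five bonds along the chain from a carbonyl carbon, here two bonds along. Within the data shown here, the one measured step of this kind was large, but compound 3 is known only as a limit. Compound 4 is expected to give 20000 nM, roughly between 5000 nM and 100000 nM. The expected step is a step that the limit leaves unreadable from compound 3 to compound 4, an estimate resting on compound 1 reaching only 4290 nM with a longer chain.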

Compound 4, concentration for 50% growth inhibition: > 10000 nM
Compound 4: a limit, no number (the forecaster's own chance of this, stated with the estimate: 70%); the middle value does not contradict the limit.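

Compound 3 and compound 4 both sit at a limit of the assay rather than at a number, so no step between them can be read: the limit of > 10000 nM in this assay, at which 2 of the 4 values shown sit.

The compounds shown leave open whether replacing hydroxycarbamoyl with (hydroxycarbamoyl)methyl changes growth inhibition at all on the core of compound 3.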